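From a 4-nitrophenyl to a 1H-pyrrol-2-yl ketone

The source may report more compounds than this note shows. Statements on the series, on what has been measured and on what is new or still open speak of the compounds shown alone.

- Compound 1 `COc1ccc(-c2cc3ccccc3nc2C=O)cc1` gives > 10000 nM (a limit, not a number)
- Compound 2 `COc1ccc(-c2cc3ccccc3nc2/C=C/C(=O)c2ccc([N+](=O)[O-])cc2)cc1` gives 6100 nM

Among the compounds with values here, in a functional assay on H184B5F5/M10 cells (Homo sapiens) for antiproliferative activity, read by XTT assay, with a stated time of 72 h (a higher number here means a weaker inhibitor, a lower number a stronger inhibitor), compound 2 gives 6100 nM, the only exact number so far. For compound 1 the result of > 10000 nM is a limit. Compound 3 `COc1ccc(-c2cc3ccccc3nc2/C=C/C(=O)c2ccc[nH]2)cc1` has 1H-pyrrol-2-yl in place of 4-nitrophenyl on a carbonyl carbon. Within the data shown here, no measured step shows what this swap does, so no change beyond the scatter is expected in this assay, and the expectation stays close to compound 2 at 6100 nM. The expected change is a 1.0-fold lower number from compound 2 to compound 3 (0.01 log units; within the scatter). For compound 3 the estimate is 6000 nM, within an expected range from 1800 nM to 15000 nM.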

Compound 3, half-maximal inhibitory concentration: > 10000 nM
Compound 3: a limit, no number; the forecaster's own chance of this, stated with the estimate: 35%; at least 1.6-fold (0.22 log units) between middle value and limit.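

In this assay, the swap to 1H-pyrrol-2-yl on the carbonyl carbon gives an at least 1.6-fold higher number from compound 2 to compound 3 (0.21 log units; that floor lies within the scatter). From the compounds shown here alone, the true size of this step is unknown, and its smallest possible size does not go beyond the scatter, so the swap shows no gain and no clear loss. The step from compound 1 to compound 3 cannot be read, as both values are limits: the limit of > 10000 nM in this assay, at which 2 of the 3 values shown sit.

Still open, going by these compounds, is how far compound 3 lies past its limit. Also open, on these data alone, is whether a 4-aminophenyl or a 4-carboxyphenyl on that carbonyl carbon would improve on compound 2, at 6100 nM.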